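Swapping the hydroxypropylamino group of compound 1

The compounds below may be only part of what the source reports. "The series", "measured", "known", "first", "only" and "open" are said of these compounds alone.

Values measured in an ADME assay on liver for metabolic stability, with Liver microsome (Homo sapiens) as the target, using microsomes; a higher number here means faster removal of the compound, a lower number slower removal:
compound 1 (`CC(=O)Nc1cc(Nc2cc(NC3CC3)n3ncc(C#N)c3n2)ccc1NCCCO`): 21 mL.min-1.g-1
compound 2 (`CC(=O)Nc1cc(Nc2cc(NC3CC3)n3ncc(C#N)c3n2)ccc1N1CCC[C@@H](N(C)C)C1`): 19 mL.min-1.g-1
compound 3 (`CC(=O)Nc1cc(Nc2cc(NC3CC3)n3ncc(C#N)c3n2)ccc1N1CC[C@H](N)C1`): < 3 mL.min-1.g-1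

Compound 1 stands level with compound 2, with a 1.1-fold lower number from compound 1 to compound 2 (0.04 log units; within the scatter). The entry for compound 3 is a limit and not a number. Compound 4 (`CC(=O)Nc1cc(Nc2cc(NC3CC3)n3ncc(C#N)c3n2)ccc1N1CC[C@@H](N)C1`) departs from compound 1 by 3-aminopyrrolidin-1-yl in place of (3-hydroxypropyl)amino on an aromatic carbon. The nearest measured step, an at least 7.0-fold lower number from compound 1 to compound 3 (0.84 log units; beyond the scatter), exchanges the same groups, and an at least 6.3-fold lower number from compound 2 to compound 3 (0.80 log units; beyond the scatter) points the same way. A step of similar size towards a lower number is therefore expected in this assay, beyond the scatter. The expected change is a 5.3-fold lower number from compound 1 to compound 4 (0.72 log units; beyond the scatter). Compound 4 is estimated at 4 mL.min-1.g-1, with an expected range from 2 mL.min-1.g-1 to 10 mL.min-1.g-1.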

Compound 4, intrinsic clearance in microsomes: < 3 mL.min-1.g-1
Compound 4 ended at the assay's limit; the forecaster's own chance of this, stated with the estimate: 45%; at least 1.3-fold (0.12 log units) between middle value and limit.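

In this assay the R form of the 3-aminopyrrolidin-1-yl group goes the same way as the S form of compound 3, with an at least 7.0-fold lower number from compound 1 to compound 4 (0.84 log units; beyond the scatter) and an at least 6.3-fold lower number from compound 2 to compound 4 (0.80 log units; beyond the scatter). The entry for compound 4 is a limit of the assay and not a number: the limit of < 3 mL.min-1.g-1 in this assay, at which 2 of the 4 values shown sit. Both ends of the step from compound 3 to compound 4 are limits, so that step cannot be read, and any effect of configuration at this stereocentre stays unseen: the fact that compounds 3 and 4 differ only in the configuration as drawn

The compounds shown leave open how far the two forms lie from each other. They also leave open whether the lower number needs the primary amine or only the five-membered ring, which a 3-hydroxypyrrolidin-1-yl group in the same place could separate.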